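The source may hold more compounds than are shown below. What is called first, only, known or untested is meant among the compounds shown, and "the series" means these compounds.

Of the compounds shown here, two built on a shared core have been tested in an assay on a cell-free system (plasma) for inhibition of lysosomal Pro-X carboxypeptidase (Mus musculus); a lower number here means a stronger inhibitor, a higher number a weaker inhibitor. Compound 1 `O=C(CCN1CCN(c2ccccc2)CC1)N1CCC[C@H]1c1nc2cc(Cl)c(Cl)cc2[nH]1` is one of them. For compound 1 the assay reports only a limit, > 10000 nM, and not a number. That reading is the limit of > 10000 nM in this assay, at which 1 of the 2 values shown sits. Compound 2 `O=C(CCN1CCC(n2ncnn2)CC1)N1CCC[C@H]1c1nc2cc(Cl)c(Cl)cc2[nH]1` is the other, and in this assay compound 2 gives 2900 nM. For the measured compounds named here, this is the only actual number among the two values shown, the other being a limit, so compound 2 stands alone as the one compound with a measured figure. Compound 3 `O=C(CCN1CCC(c2nc(-c3cnccn3)no2)CC1)N1CCC[C@H]1c1nc2cc(Cl)c(Cl)cc2[nH]1` differs from compound 2 in one place: a group of 11 heavy atoms (6 carbon, 4 nitrogen, 1 oxygen; one five-membered aromatic ring with 3 hetero atoms, one six-membered aromatic ring with 2 hetero atoms) in place of a group of 5 heavy atoms (1 carbon, 4 nitrogen; one five-membered aromatic ring with 4 hetero atoms), on a saturated ring carbon. Going by the values given here, no measured pair differs in just this way, so the size of the step is open. With compound 2 as the only anchor, the expectation is a step in this assay of modest size, with no clear direction, and probably not far beyond the usual scatter. Compound 3 is therefore expected to give 2000 nM, within a range of 400 nM to 10000 nM, which amounts to an expected step from compound 2 to compound 3 of a 1.5-fold lower number from compound 2 to compound 3 (0.16 log units; within the scatter).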

Compound 3, half-maximal inhibitory concentration: 435 nM
Compound 3: middle estimate off by 4.6-fold (0.66 log units), on the high side, within the range that was stated.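

In this assay, this saturated ring carbon proves to be a place where the choice of group matters: putting a group of 11 heavy atoms, with one five-membered aromatic ring with 3 hetero atoms and one six-membered aromatic ring with 2 hetero atoms, in place of 2H-tetrazol-2-yl gives a 6.7-fold lower number from compound 2 to compound 3 (0.82 log units; beyond the scatter). The position therefore tolerates a group with more heavy atoms than 2H-tetrazol-2-yl, and the number falls rather than rises with this change, which a single measured figure could not show. Heavy atoms, rings and hydrogen-bond acceptors all change together in this one step, and nothing measured here bears on which of these differences accounts for the result.

From the compounds shown here alone, it remains open whether the five-membered aromatic ring alone would give the same result, or whether the six-membered aromatic ring is needed, for instance if a methyl group took its place. A carboxylic acid or a simple amine on the same saturated ring carbon would show whether the number depends on aromatic rings at this position at all.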